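The source may hold more compounds than are shown below. What is called first, only, known or untested is meant among the compounds shown, and "the series" means these compounds.

For the measured compounds named here, in a functional assay on HT-29 cells (Homo sapiens) for cytotoxicity, read by MTT assay, with a stated time of 72 h (a higher number here means a weaker inhibitor, a lower number a stronger inhibitor), compound 1 (`O=C(CN1CCN(c2nnc(Cc3ccncc3)c3ccccc23)CC1)Nc1ccc(Br)cc1`) gives 1990 nM as the lowest of the three numbers measured so far. Compound 3 (`O=C(CN1CCN(c2nnc(Cc3ccccc3)c3ccccc23)CC1)Nc1ccc(Br)cc1`) stands at 60200 nM and compound 2 (`Cc1ccc(F)cc1NC(=O)CN1CCN(c2nnc(Cc3ccccc3)c3ccccc23)CC1`) at 171000 nM on the same scale. Compound 4 (`Cc1ccccc1NC(=O)CN1CCN(c2nnc(Cc3ccncc3)c3ccccc23)CC1`) has not been measured yet. It differs from compound 1 in one place, with 2-methylphenyl in place of 4-bromophenyl on an amide-type nitrogen. The closest evidence is a 2.8-fold lower number from compound 2 to compound 3 (0.45 log units; beyond the scatter) when 4-bromophenyl replaces 5-fluoro-2-methylphenyl on that nitrogen. That group is not quite 2-methylphenyl, and those two compounds carry phenyl where compound 1 carries pyridin-4-yl, so the guide is imperfect. The other step is a 30-fold higher number from compound 1 to compound 3 (1.48 log units; beyond the scatter) and it swaps pyridin-4-yl for phenyl, a change compound 4 does not make, so it says little here. A modest rise in the number is therefore expected, and the expected step is a 2.5-fold higher number from compound 1 to compound 4 (0.40 log units; beyond the scatter) with wide uncertainty. In this assay compound 4 is estimated at 5000 nM with a range of 1500 nM to 17000 nM expected.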

Compound 4, half-maximal inhibitory concentration: 15000 nM
Estimate against measurement, compound 4: 3.0-fold (0.48 log units) below, and the stated range covers the measured number.
By their numbers in this assay, from the lowest: compound 1; then compound 4; then compound 3; then compound 2.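

In this assay, for the compounds shown here, a 7.5-fold higher number from compound 1 to compound 4 (0.88 log units; beyond the scatter) gives the first reading of this amide-type nitrogen in a compound that carries pyridin-4-yl, and the step is modest but beyond the scatter. It points the same way as a 2.8-fold lower number from compound 2 to compound 3 (0.45 log units; beyond the scatter), since in both pairs the compound with 4-bromophenyl has the lower number, although that earlier pair compares it with 5-fluoro-2-methylphenyl and carries phenyl instead of pyridin-4-yl. The two groups exchanged here have the same count of heavy atoms and no hydrogen-bond donors or acceptors, and nothing measured explains the shift in the number.

The compounds shown cannot separate the effect of removing the bromine from that of changing the substituent's place on the ring. A 4-methylphenyl or an unsubstituted phenyl on this nitrogen would help to separate them.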